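Fluoromethyl to aminomethyl at the antiproliferative limit

This account rests on a few compounds, and the source may have more. Where it says the series, first, only, none or still open, it means among the compounds named here.

Compound 1 `Cc1cn([C@H]2C[C@H](CF)[C@@H](CO)O2)c(=O)[nH]c1=O`: > 100 uM
Compound 2 `Cc1cn([C@@H]2O[C@H](CO)[C@@H](CF)[C@H]2O)c(=O)[nH]c1=O`: > 100 uM

Both entries come from a functional assay on CCRF-CEM cells (Homo sapiens) for antiproliferative activity, with a stated time of 72 h (on this read-out lower numbers stand for an effect already at smaller amounts and higher numbers for an effect only at larger amounts of compound), and each is a limit of the assay and not a number. Compound 2 shares (the limit of > 100 uM in this assay, at which 2 of the 2 values shown sit), so it has no readable position relative to compound 1. Within the data shown here, the one measured step, a step that the two limits leave unreadable from compound 1 to compound 2, is hydroxy in place of hydrogen on a saturated ring carbon.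

Compound 3 `Cc1cn([C@@H]2O[C@H](CO)[C@@H](CN)[C@H]2O)c(=O)[nH]c1=O` carries a different change, amino in place of fluoro on a saturated chain carbon bound to a saturated ring carbon, or fluoromethyl to aminomethyl. The measured step does not make this exchange and gives it no size, so no direction of change in this assay can be drawn from it. The expectation therefore rests on compound 2 at > 100 uM, a limit, and another limit is the likely report.

The estimated step is a step that the limit leaves unreadable from compound 2 to compound 3. For compound 3 the estimated value is 150 uM, with an expected range from 50 uM to 400 uM.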

Compound 3, concentration for half-maximal effect: > 100 uM
Compound 3: only a limit was reported (the forecaster's own chance of this, stated with the estimate: 85%); the middle value is on the limit's open side.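

In this assay compound 3 gives > 100 uM as a limit of the assay and not a number. No step can be read from compound 2 to compound 3 or among the three compounds, as all of them sit at one limit: the limit of > 100 uM in this assay, at which 3 of the 3 values shown sit.

From the compounds shown here alone, how fluoromethyl and aminomethyl compare on these cells remains open, as does where any of the three compounds would reach a half-maximal effect.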